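This account rests on a few compounds, and the source may have more. Where it says the series, first, only, none or still open, it means among the compounds named here.

Compound 1 `CN(C)CCn1cnnc1-c1cc(Oc2ccc(NC(=O)N/N=C/c3ccc(O)c(Br)c3)cc2F)ccn1`: 430 nM
Compound 2 `COc1cc(/C=N/NC(=O)Nc2ccc(Oc3ccnc(-c4nncn4CCN(C)C)c3)c(F)c2)cc(OC)c1OC`: 2770 nM
Compound 3 `CN(C)CCn1cnnc1-c1cc(Oc2ccc(NC(=O)N/N=C/c3ccc(O)c(F)c3)cc2F)ccn1`: 2620 nM

All three were tested in a functional assay on NCI-H460 cells (Homo sapiens) for cytotoxicity, read by MTT assay, with a stated time of 72 h; a higher number here means a weaker inhibitor, a lower number a stronger inhibitor. Compound 1 gives the lowest number of the three, and since both a 6.4-fold higher number from compound 1 to compound 2 (0.81 log units; beyond the scatter) and a 6.1-fold higher number from compound 1 to compound 3 (0.78 log units; beyond the scatter) lie beyond the scatter, compound 1 is the strongest inhibitor among the measured compounds. Compounds 2 and 3 sit within the scatter of each other, as a 1.1-fold lower number from compound 2 to compound 3 (0.02 log units; within the scatter) shows.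

Compound 4 `CN(C)CCn1cnnc1-c1cc(Oc2ccc(NC(=O)N/N=C/c3ccc(O)cc3O)cc2F)ccn1` has not yet been measured. It differs from compound 1 in one place: 2,4-dihydroxyphenyl in place of 3-bromo-4-hydroxyphenyl on a carbon with a double bond to nitrogen Two measured steps bear on this change, as each also swaps the group on the carbon with a double bond to nitrogen: a 6.4-fold higher number from compound 1 to compound 2 (0.81 log units; beyond the scatter) and a 6.1-fold higher number from compound 1 to compound 3 (0.78 log units; beyond the scatter). Each replacement of the 3-bromo-4-hydroxyphenyl raised the number by a modest amount. Neither matches the entering 2,4-dihydroxyphenyl exactly, so compound 4 is expected to show a similar modest rise: a 4.7-fold higher number from compound 1 to compound 4 (0.67 log units; beyond the scatter). Compound 4 is therefore estimated to give about 2000 nM in this assay, within a likely range of 600 nM to 6500 nM.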

Compound 4, half-maximal inhibitory concentration: 11300 nM
Estimate against measurement, compound 4: 5.7-fold (0.75 log units) below; measured number outside the range, above it.
By their numbers in this assay, from the lowest: compound 1; then compounds 3 and 2 (each within the scatter of the next); then compound 4.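

At this position on the carbon with a double bond to nitrogen, the earlier swaps made compounds 2 and 3 weaker than compound 1 by similar amounts, but 2,4-dihydroxyphenyl reaches further (a 26-fold higher number from compound 1 to compound 4 (1.42 log units; beyond the scatter)). It also separates clearly from the two earlier replacements (a 4.3-fold higher number from compound 3 to compound 4 (0.63 log units; beyond the scatter); a 4.1-fold higher number from compound 2 to compound 4 (0.61 log units; beyond the scatter)), so in this assay the groups here span a wider range than the first three compounds suggested, and compound 4 is the weakest of the four. Nothing measured here explains why this group gives the highest number.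

Open, as far as these compounds go, is whether the second hydroxyl or the missing halogen matters more, which a plain 4-hydroxyphenyl group would help to separate. A chloro or iodo group in place of the bromo would test whether the low number of compound 1 is particular to bromine.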